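The compounds below may be only part of what the source reports. "The series", "measured", "known", "first", "only" and "open" are said of these compounds alone.

Of the compounds shown here, two have so far been measured in a physicochemical assay for solubility, in phosphate buffer, with a stated time of 24 h, at pH 7.2; a lower number here means a less soluble compound, a higher number a more soluble compound. Compound 1 `O=C(c1ccc(-c2cncc(F)c2)s1)c1cc(F)c(F)c(O)c1F` gives > 200000 nM, which is a limit of the assay and not a number. Compound 2 `Cc1cc(-c2ccc(C(=O)c3cc(F)c(F)c(O)c3F)s2)cc(C)c1O` gives > 200000 nM, also a limit of the assay. Both results sit at the limit of > 200000 nM in this assay, at which 2 of the 2 values shown sit, so compound 2 stands where every value shown stands. Compound 3 `Cc1cc(-c2ccc(C(=O)c3cc(F)c(F)c(O)c3C)s2)cc(C)c1O` differs from compound 2 by methyl in place of fluoro on an aromatic carbon. For the measured compounds named here, no step between measured compounds is available to guide the expectation, so the step in this assay a number no higher from compound 2 to compound 3 (the limit leaves the size open) is expected to be none beyond the usual scatter. Compound 3 is accordingly estimated at 200000 nM, with a range from 70000 nM to 400000 nM.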

Compound 3, solubility: 15000 nM
Estimate against measurement, compound 3: 13-fold (1.12 log units) above; measured number outside the range, below it.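

In this assay, methyl in place of fluoro on an aromatic carbon, ortho to a hydroxy group, gives an at least 13-fold lower number from compound 2 to compound 3 (1.12 log units; beyond the scatter). One heavy atom replaces one heavy atom, with no hydrogen-bond donor or acceptor entering or leaving, yet this single change brings the read-out to a number rather than a limit. The full size of the step stays open, as compound 2 stands at a limit of the assay: the limit of > 200000 nM in this assay, at which 2 of the 3 values shown sit.

From the compounds shown here alone, whether chloro, methoxy or an amine at this place would also lower the number stays open. So does whether the same change would do so on compound 1.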